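This account rests on a few compounds, and the source may have more. Where it says the series, first, only, none or still open, it means among the compounds named here.

Compound 1 `CC1=C(C(=O)Nc2cccc([N+](=O)[O-])c2)C(c2ccc(O)cc2O)NC(SCc2ccccc2)=N1`: > 100000 nM
Compound 2 `CC1=C(C(=O)Nc2cccc([N+](=O)[O-])c2)C(c2ccc(O)cc2O)NC(Nc2ccc(S(=O)(=O)Nc3ncccn3)cc2)=N1`: 69200 nM

Going by the values given here, in a functional assay on A-431 cells (Homo sapiens) for inhibition, read by sulforhodamine B assay, with a stated time of 2 days (on this read-out higher numbers stand for weaker inhibition of growth and lower numbers for stronger inhibition of growth), compound 2 gives 69200 nM, the only true number available so far. Compound 1 gives > 100000 nM, which is a limit of the assay and not a number. Compound 2 therefore has no measured neighbour to be ranked against, and its value can only be read on its own.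

The next compound, compound 3 `CC1=C(C(=O)Nc2cccc([N+](=O)[O-])c2)C(c2ccc(O)cc2O)NC(Nc2ccc(S(=O)(=O)Nc3nc(C)cc(C)n3)cc2)=N1`, keeps the shared core and changes one group: 4,6-dimethylpyrimidin-2-yl in place of pyrimidin-2-yl on a sulfonamide nitrogen. In words, a 4,6-dimethylpyrimidin-2-yl sits in place of pyrimidin-2-yl on a sulfonamide nitrogen.

Among the compounds with values here, no measured pair in this small set shows what such a change does in this assay. The expectation therefore rests on compound 2 at 69200 nM, with no firm direction and no change beyond the usual scatter. The expected outcome is a 1.2-fold lower number from compound 2 to compound 3 (0.06 log units; within the scatter). A result reported only as a limit also remains possible. For compound 3 the estimate is 60000 nM, with an expected range of 25000 nM to 100000 nM.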

Compound 3, concentration for 50% growth inhibition: 3940 nM
Estimate against measurement, compound 3: 15-fold (1.18 log units) above; measured number below the stated range.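

In this assay, the ring on the sulfonamide nitrogen proves to be a place where a small edit matters: putting 4,6-dimethylpyrimidin-2-yl in place of pyrimidin-2-yl gives an 18-fold lower number from compound 2 to compound 3 (1.24 log units; beyond the scatter), which means stronger inhibition of growth. The two groups have the same kind of six-membered aromatic ring with the same hydrogen-bond donor and acceptor counts and no net charge, so the two methyl groups are the whole difference, and they are enough to move a weak compound well beyond the scatter. Compound 1 is reported only as a limit and not a number, so no step to it can be read: the limit of > 100000 nM in this assay, at which 1 of the 3 values shown sits.

This single pair shows that the methyl-bearing ring gives the lower number, but it cannot show how the methyl groups achieve this, or whether both are needed. Also open, going by these compounds, is whether one methyl group, a longer ethyl chain or a methoxy group on the same ring would do as well, and whether the same swap would give a similar step on a different shared core.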